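A side-chain swap on a short-lived compound

A few compounds are considered here, and "the series" means these few. Any claim that something is new, unique, unknown or untested is made for them only; others in the source may bear on it.

In an ADME assay (liver) for metabolic stability, with Liver microsome (Homo sapiens) as the target, using microsomes (on this read-out higher numbers stand for a longer-lived compound and lower numbers for a shorter-lived compound), compound 1 (`CC(C)OC(=O)N1CCC(O[C@H]2CC[C@H](Oc3cnc(S(C)(=O)=O)cn3)CC2)CC1`) gives > 1 h as a limit of the assay and not a number. Going by the values given here, compound 2 (`CS(=O)(=O)c1cnc(O[C@H]2CC[C@H](OC3CCN(CC4(C(F)(F)F)CC4)CC3)CC2)cn1`) gives 0.35 h as the only exact number so far. Compound 3 (`CC(C)c1noc(CN2CCC(O[C@H]3CC[C@H](Oc4cnc(S(C)(=O)=O)cn4)CC3)CC2)n1`) carries 3-isopropyl-1,2,4-oxadiazol-5-yl in place of 1-(trifluoromethyl)cyclopropyl on a saturated chain carbon bound to an amine nitrogen in a ring. Among the compounds with values here, the one measured step (an at least 2.8-fold lower number from compound 1 to compound 2 (0.45 log units; beyond the scatter)) starts from that limit (the limit of > 1 h in this assay, at which 1 of the 2 values shown sits) and exchanged different groups, so no step beyond the scatter is expected. Compound 3 is estimated at 0.4 h (0.15 h to 1 h) in this assay as an expectation. That expected step is a 1.1-fold higher number from compound 2 to compound 3 (0.06 log units; within the scatter) in size.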

Compound 3, half-life: > 1 h
Compound 3 gave a limit, no number; the forecaster's own chance of this, stated with the estimate: 10%; middle value at least 2.5-fold (0.39 log units) from the limit.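

On the saturated chain carbon bound to an amine nitrogen in a ring, 3-isopropyl-1,2,4-oxadiazol-5-yl in place of 1-(trifluoromethyl)cyclopropyl gives, in this assay, an at least 2.8-fold higher number from compound 2 to compound 3 (0.45 log units; beyond the scatter). A change at this one place is therefore enough to move the read-out beyond the scatter. The step between compound 1 and compound 3 cannot be read, because both stand at a limit: the limit of > 1 h in this assay, at which 2 of the 3 values shown sit.

Going by these compounds, how far compound 3 lies past its limit stays open. So does whether a plain phenyl group or a carboxylic acid in the same place would also give a longer-lived compound than compound 2.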